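Methoxy for methyl on compound 2

A few compounds are considered here, and "the series" means these few. Any claim that something is new, unique, unknown or untested is made for them only; others in the source may bear on it.

In a functional assay on MCF7 cells (Homo sapiens) for antiproliferative activity, read by MTT assay, with a stated time of 48 h (a lower number here means a stronger inhibitor, a higher number a weaker inhibitor), compound 2 `Cc1ccc(C(=O)/C=C/c2cccc(Cl)c2Oc2c([N+](=O)[O-])cc(C(F)(F)F)cc2[N+](=O)[O-])cc1` gives 0.03 ug/mL as the lowest of the three numbers, beyond the scatter from both others. Compound 1 `Cc1ccc(C(=O)/C=C/c2cccc(Br)c2Oc2c([N+](=O)[O-])cc(C(F)(F)F)cc2[N+](=O)[O-])cc1` stands at 0.55 ug/mL and compound 3 `COc1ccc(C(=O)/C=C/c2cc(Br)cc(Br)c2Oc2c([N+](=O)[O-])cc(C(F)(F)F)cc2[N+](=O)[O-])cc1` at 3.53 ug/mL in the same read-out. Compound 4 `COc1ccc(C(=O)/C=C/c2cccc(Cl)c2Oc2c([N+](=O)[O-])cc(C(F)(F)F)cc2[N+](=O)[O-])cc1` has methoxy in place of methyl on an aromatic carbon, para to a large group (methoxy in place of methyl on an aromatic carbon). Among the measured compounds shown here, no measured step covers this change. The only one is an 18-fold lower number from compound 1 to compound 2 (1.26 log units; beyond the scatter) for chloro in place of bromo, which is large but lies elsewhere. Compound 3 carries methoxy but also differs in its halogens, so its 3.53 ug/mL points upward only weakly. The expected step in this assay is a 5.0-fold higher number from compound 2 to compound 4 (0.70 log units; beyond the scatter) toward a weaker inhibitor. Compound 4 is estimated at 0.15 ug/mL within an expected range of 0.02 ug/mL to 1 ug/mL for now.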

Compound 4, half-maximal inhibitory concentration: 1.83 ug/mL
Compound 4: the middle estimate sits 12-fold (1.09 log units) below what was measured, and the stated range ends below it.
By their numbers in this assay, from the lowest: compound 2; then compound 1; then compounds 4 and 3 (each within the scatter of the next).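

In this assay, 4-methylphenyl to 4-methoxyphenyl gives a 61-fold higher number from compound 2 to compound 4 (1.79 log units; beyond the scatter), toward a weaker inhibitor. Among the compounds shown here, the earlier step concerned only the halogen, so this is the first clean sign that the (4-methylphenyl)carbonyl end also governs the read-out, with methyl the better of the two groups here. Nothing available explains the size of this step.

Going by these compounds, whether hydrogen, fluoro, an amine or ethoxy at this place would keep a number near that of compound 2 remains open. Also open, on these data alone, is whether the same change gives a similar step with bromo in place of chloro.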